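The compounds below may be only part of what the source reports. "The series", "measured", "known", "first", "only" and "open" are said of these compounds alone.

- compound 1 `CC(Nc1ccccc1Oc1ccc(Cl)cc1)=C1C(=O)CC(c2ccccc2)CC1=O`: 500 nM
- compound 2 `COc1cc(Oc2ccccc2NC(C)=C2C(=O)CC(c3ccccc3)CC2=O)ccc1N`: 33 nM
- compound 3 `CCOc1ccccc1NC(C)=C1C(=O)CC(c2ccccc2)CC1=O`: 180 nM

In a functional assay on HeLa cells (Homo sapiens) for antiproliferative activity, read by cell counting, with a stated time of 3 days (on this read-out lower numbers stand for stronger inhibition and higher numbers for weaker inhibition), compound 3 gives 180 nM, which puts it in the middle of the three: compound 1 has the highest number and compound 2 the lowest. The next molecule, compound 4 `CC(Nc1ccccc1Oc1cccc(N)c1)=C1C(=O)CC(c2ccccc2)CC1=O`, keeps the shared core and changes one group: 3-aminophenyl in place of ethyl on an oxygen on an aromatic ring. In words, 3-aminophenyl takes the place of ethyl on an oxygen on an aromatic ring.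

Among the measured compounds shown here, three measured steps bear on this change, all at the same place. Putting 4-amino-3-methoxyphenyl in place of 4-chlorophenyl gave a 15-fold lower number from compound 1 to compound 2 (1.18 log units; beyond the scatter), a large step. Ethyl in place of 4-amino-3-methoxyphenyl gave a 5.5-fold higher number from compound 2 to compound 3 (0.74 log units; beyond the scatter), while ethyl in place of 4-chlorophenyl gave a 2.8-fold lower number from compound 1 to compound 3 (0.44 log units; beyond the scatter). So a ring on that oxygen has gone with both the lowest and the highest number, and the ring carrying an amino group gave the lowest. For the measured compounds named here, compound 4 also has an amino group on its ring but no methoxy, and no measured compound separates the two groups. A modest step towards lower numbers therefore seems likely in this assay, probably smaller than the gap between the values of compound 3 and compound 2.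

The expected value for compound 4 is 70 nM, with an estimated range from 25 nM to 200 nM. This estimate means an expected 2.6-fold lower number from compound 3 to compound 4 (0.41 log units; beyond the scatter).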

Compound 4, half-maximal inhibitory concentration: 82 nM
Beside the measured number, compound 4's estimate is 1.2-fold (0.07 log units) below it, and the stated range covers the measured number.
By their numbers in this assay, from the lowest: compound 2; then compound 4; then compound 3; then compound 1.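

Going from ethyl to 3-aminophenyl gives a 2.2-fold lower number from compound 3 to compound 4 (0.34 log units; beyond the scatter) in this assay, so a ring on this oxygen can improve on ethyl even without a methoxy group. A ring as such does not settle the outcome: 3-aminophenyl in place of 4-chlorophenyl gives a 6.1-fold lower number from compound 1 to compound 4 (0.79 log units; beyond the scatter) and, among these four, the two rings carrying an amino group have the two lowest numbers, while the ring carrying chlorine has the highest. The 4-amino-3-methoxyphenyl ring remains ahead, since exchanging it for 3-aminophenyl gives a 2.5-fold higher number from compound 2 to compound 4 (0.40 log units; beyond the scatter) and shows that the amino group alone, at least as placed here, does not reach the lowest number.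

As far as these compounds go, that last change moves the amino group and removes the methoxy group together, so the share of each remains unknown, and neither an unsubstituted phenyl ring nor a ring bearing a hydroxyl group or a 4-amino group alone appears here to show how much the amino group itself contributes. No supporting measurement is available to explain why these rings differ in this cell read-out.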